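The source may hold more compounds than are shown below. What is called first, only, known or untested is meant among the compounds shown, and "the series" means these compounds.

In a functional assay on MDA-MB-231 cells (Homo sapiens) for antiproliferative activity, read by MTT assay, with a stated time of 24 h (a lower number here means a stronger inhibitor, a higher number a weaker inhibitor), the measured compounds stand as follows:
Compound 1 `COc1ccc(C(=O)/C=C/c2cc(-c3cc(OC)c(OC)c(OC)c3)n3nc(-c4ccccc4)cc3n2)cc1` gives 13200 nM.
Compound 2 `COc1cc(C(=O)/C=C/c2cc(-c3cc(OC)c(OC)c(OC)c3)n3nc(-c4ccccc4)cc3n2)cc(OC)c1OC` gives 24300 nM.
Compound 3 `COc1ccc(/C=C/C(=O)c2cc(-c3ccc(OC)c(OC)c3)n3nc(-c4ccccc4)cc3n2)cc1` gives 22000 nM.

Compound 3 stands second highest of these three numbers in this assay, with compound 2 nearest and compound 1 furthest, and both gaps lie within the scatter, so the three numbers cannot be told apart. Compound 4 `COc1ccc(-c2cc(C(=O)/C=C/c3ccc(Cl)cc3)nc3cc(-c4ccccc4)nn23)cc1OC` has not yet been measured. It differs from compound 3 in one place: chloro in place of methoxy on an aromatic carbon. Within the data shown here, only one measured step exists, a 1.8-fold higher number from compound 1 to compound 2 (0.27 log units; within the scatter), and it exchanges the group on a carbonyl carbon rather than a group on an aromatic carbon, so it speaks only indirectly to the present change; it shows that one exchange of a whole aryl group moved the number little. Among the measured compounds shown here, no measured step bears directly on a methoxy-to-chloro exchange, so no step beyond the scatter is expected in this assay in either direction. Compound 4 is therefore expected to give about 22000 nM, between 8000 nM and 60000 nM, which amounts to an expected step of no change at the digits printed from compound 3 to compound 4 (within the scatter).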

Compound 4, half-maximal inhibitory concentration: 23700 nM
Compound 4: middle estimate off by 1.1-fold (0.03 log units), on the low side, within the range that was stated.
By their numbers in this assay, from the lowest: compounds 1, 3, 4 and 2 (each within the scatter of the next).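

Among these compounds, this is the first measured exchange at this position: chloro takes the place of methoxy on an aromatic carbon, para to a large group, whereas the earlier step exchanged a whole aryl group on a carbonyl carbon. In this assay, the exchange gives a 1.1-fold higher number from compound 3 to compound 4 (0.03 log units; within the scatter), so a 4-chlorophenyl and a 4-methoxyphenyl group at this place cannot be told apart by this read-out. No available measurement offers an explanation for this result.

From the compounds shown here alone, whether a quite different group here, such as an amine or a carboxylic acid, would give a step beyond the scatter remains open. Also open, going by these compounds, is whether any single change to these compounds can do so, since each of the four numbers lies within the scatter of the next.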